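Replacing the hydroxycarbamoyl end of compound 2

The source may report more compounds than this note shows. Statements on the series, on what has been measured and on what is new or still open speak of the compounds shown alone.

Measured in a functional assay on PLC-PRF-5 cells (Homo sapiens) for inhibition, read by MTT assay, with a stated time of 72 h; a higher number here means a weaker inhibitor, a lower number a stronger inhibitor:
- compound 1 `CNC(=O)CCCCCCCn1nc(-c2cnc3[nH]ccc3c2)c2c(N)ncnc21`: 35900 nM
- compound 2 `Nc1nc2cc(-c3nn(CCCCCC(=O)NO)c4ncnc(N)c34)ccc2o1`: > 50000 nM

Among the compounds with values here, only two measurements are available, and no step between measured compounds can be read from them. Compound 2 gives only a limit of this assay, > 50000 nM, and no number. This places it at the limit of > 50000 nM in this assay, at which 1 of the 2 values shown sits.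

Compound 3 `CNC(=O)CCCCCCCn1nc(-c2ccc3oc(N)nc3c2)c2c(N)ncnc21` is the next member to be read. Relative to compound 2, it carries 2-(methylcarbamoyl)ethyl in place of hydroxycarbamoyl on a saturated chain carbon, five bonds along the chain from an aromatic nitrogen.

Within the data shown here, the only numerical reading, compound 1 at 35900 nM, serves as the anchor for the expectation. In this assay, a small shift towards a stronger inhibitor is expected, though no real change is also plausible, and a second limit reading would not be surprising. The estimated change is an at least 1.1-fold lower number from compound 2 to compound 3 (0.07 log units; that floor lies within the scatter). For compound 3, the expected value is 42000 nM, with an estimated range of 18000 nM to 90000 nM.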

Compound 3, half-maximal inhibitory concentration: 30500 nM
Compound 3: the middle estimate sits 1.4-fold (0.14 log units) above what was measured; low and high end bracket the measured number.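

In this assay, within the data shown here, 2-(methylcarbamoyl)ethyl in place of hydroxycarbamoyl gives a first step at this position, an at least 1.6-fold lower number from compound 2 to compound 3 (0.21 log units; that floor lies within the scatter), so the true size of the change remains unknown and it cannot be called a real gain. That step is only a floor, and the entry for compound 2 is a limit, not a number: the limit of > 50000 nM in this assay, at which 1 of the 3 values shown sits. With the 7-(methylcarbamoyl)heptyl-type end held constant is not a reading available here, but the aromatic group can be compared directly: a 1.2-fold lower number from compound 1 to compound 3 (0.07 log units; within the scatter), so the two aromatic groups on the aromatic carbon are not told apart in this assay.

The step from compound 2 to compound 3 changes the end group and the chain length together, so the compounds shown leave open which of the two matters; a hydroxycarbamoyl end on the longer chain of compound 3 would separate them. Also open, as far as these compounds go, is how a carboxylic acid or a primary amide at the same chain end would read in this assay.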